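Shortening the Chain on a Fused Core: Compound 4

A few compounds are considered here, and "the series" means these few. Any claim that something is new, unique, unknown or untested is made for them only; others in the source may bear on it.

Compound 1 `Cn1cc2c(Cl)nc(NC(=O)c3ccccc3)nc2n1`: > 20000 nM (a limit)
Compound 2 `CC(C)(C)Cn1cc2c(Cl)nc(NC(=O)c3ccccc3)nc2n1`: >= 10000 nM (a limit)
Compound 3 `CC(C)(C)Cn1cc2c(Cl)nc(N)nc2n1`: > 10000 nM (a limit)

In a functional assay on CHO cells for antagonist activity at adenosine receptor A2b (Homo sapiens), read by 33P incorporation, with a stated time of 20 min, in the presence of a further agent that is not named here (on this read-out higher numbers stand for weaker inhibition and lower numbers for stronger inhibition), compound 1 gives > 20000 nM, which is a limit of the assay and not a measured number. Compound 2 gives >= 10000 nM, also a limit. Compound 3 gives > 10000 nM, again a limit, so compound 3 stands nowhere precisely; all three values in this assay are limits, none is a number.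

The steps between them are therefore unreadable: a step that the two limits leave unreadable from compound 1 to compound 2 and a step that the two limits leave unreadable from compound 2 to compound 3 cannot be sized, as the limit of > 20000 nM in this assay, at which 1 of the 3 values shown sits, the limit of >= 10000 nM in this assay, at which 1 of the 3 values shown sits, and the limit of > 10000 nM in this assay, at which 1 of the 3 values shown sits, show.

Compound 4 `CC(C)n1cc2c(Cl)nc(N)nc2n1` differs from compound 3 by isopropyl in place of neopentyl on an aromatic nitrogen. Among the compounds with values here, the only measured change on that aromatic nitrogen, from compound 1 to compound 2, is unreadable, so no measured step sets a size or direction for this one. A step beyond the scatter is not expected; compound 4 is expected to sit at a limit as well, estimated at 20000 nM with a range from 5000 nM to 80000 nM, an expected step that the limit leaves unreadable from compound 3 to compound 4.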

Compound 4, inhibition constant: > 10000 nM
Compound 4 gave a limit, no number; the forecaster's own chance of this, stated with the estimate: 85%; the middle value does not contradict the limit.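

No step can be sized between compound 3 and compound 4, because each gives only a limit and not a number: the limit of > 10000 nM in this assay, at which 2 of the 4 values shown sit. The compounds shown leave open whether any group on that aromatic nitrogen yields a measurable number in this assay.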